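The source may hold more compounds than are shown below. What is called first, only, known or untested is meant among the compounds shown, and "the series" means these compounds.

Compound 1 `O=C1NC(=S)S/C1=C\c1cc2cc(Cl)ccc2nc1Cl` and compound 2 `O=C1NC(=S)S/C1=C\c1cc2cc(F)ccc2nc1Cl` share one core and differ in a single place. In a toxicity assay on THP-1 cells (Homo sapiens) for cytotoxicity, read by MTT assay, with a stated time of 48 h (a higher number here means a weaker inhibitor of growth, a lower number a stronger inhibitor of growth), compound 1 gives > 100 ug/mL, which is a limit of the assay rather than a number. In this assay compound 2 likewise gives > 100 ug/mL, again a limit. The step that the two limits leave unreadable from compound 1 to compound 2 therefore cannot be read. Compound 2 thus stands where compound 1 stands: the limit of > 100 ug/mL in this assay, at which 2 of the 2 values shown sit.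

Compound 3 `O=C(O)CN1C(=O)/C(=C/c2cc3cc(F)ccc3nc2Cl)SC1=S` differs from compound 2 in one place: carboxymethyl in place of hydrogen on an amide-type nitrogen in a ring. Among the compounds with values here, the only measured step, from compound 1 to compound 2, concerns a different part of the molecule and its size is unreadable, so no measured step tells how large the change in this assay from compound 2 to compound 3 will be, or in which direction. Both measured values sit at the limit, and the plain expectation is that compound 3 will again come out near that limit. Compound 3 is therefore estimated at 100 ug/mL, with a range from 40 ug/mL to 250 ug/mL. The step this estimate implies, a number no higher from compound 2 to compound 3 (the limit leaves the size open), is expected to stay within the scatter.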

Compound 3, concentration for 50% growth inhibition: > 100 ug/mL
Compound 3: a limit, no number (the forecaster's own chance of this, stated with the estimate: 70%); the middle value lies on the limit itself.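

Compound 3, like compound 2, gives only a limit and not a number, so no size can be read for the step that puts carboxymethyl in place of hydrogen on the amide-type nitrogen: the limit of > 100 ug/mL in this assay, at which 3 of the 3 values shown sit.

The compounds shown leave open how strongly any of them inhibits growth in this assay, and whether either single change shifts that at all.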